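This account rests on a few compounds, and the source may have more. Where it says the series, first, only, none or still open, it means among the compounds named here.

In a functional assay on A549 cells (Homo sapiens) for inhibition, read by MTT assay, with a stated time of 48 h (on this read-out lower numbers stand for stronger inhibition of growth and higher numbers for weaker inhibition of growth), compound 1 `Cn1cc(C2CC(c3ccccc3)=NN2C(=O)c2cccnc2)c2ccccc21` gives > 10000 nM, which is a limit of the assay and not a number. Compound 1 therefore stands at the weak end of the numbers shown, with the limit of > 10000 nM in this assay, at which 1 of the 3 values shown sits. Compound 2 `COc1ccc(C(=O)N2N=C(c3ccccc3)CC2c2cn(C)c3ccccc23)cn1` gives 3040 nM, and compound 3 `Cn1cc(C2CC(c3ccccc3)=NN2C(=O)c2ccncc2)c2ccccc21` gives 990 nM.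

Compound 4 `Cn1cc(C2CC(c3ccccc3)=NN2C(=O)c2cccnc2)c2cc(Br)ccc21` keeps the pyridin-3-yl on the carbonyl carbon of compound 1 and changes the core: bromo in place of hydrogen on an aromatic carbon. This puts bromo in place of hydrogen on a six-membered aromatic ring of carbon only, part of a fused system.

Among the measured compounds shown here, no measured step touches that ring. The nearest guide is an at least 3.2-fold lower number from compound 1 to compound 2 (0.51 log units; beyond the scatter), where methoxy also replaces hydrogen on an aromatic carbon, though elsewhere in the molecule. The other steps, an at least 10-fold lower number from compound 1 to compound 3 (1.00 log units; beyond the scatter) and a 3.1-fold lower number from compound 2 to compound 3 (0.49 log units; beyond the scatter), exchange the group on the carbonyl carbon and bear on this change only loosely. A modest move towards lower numbers is therefore expected, with real doubt about its size.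

The expected change is an at least 2.0-fold lower number from compound 1 to compound 4 (0.30 log units; that floor lies within the scatter). For compound 4 the estimated value is 5000 nM, with an expected range from 1500 nM to 15000 nM.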

Compound 4, concentration for 50% growth inhibition: 1600 nM
Beside the measured number, compound 4's estimate is 3.1-fold (0.49 log units) above it; the range from low to high includes it.
By their numbers in this assay, from the lowest: compounds 3, 4 and 2 (each within the scatter of the next, the first and the last beyond it). At a limit, above all of these: compound 1.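

Every earlier step changed the group on the carbonyl carbon, while this one leaves that group alone and changes the core. In this assay, bromo in place of hydrogen on the six-membered aromatic ring of carbon only gives an at least 6.2-fold lower number from compound 1 to compound 4 (0.79 log units; beyond the scatter), so the core's fused ring system is also a place where a single atom can shift the growth-inhibition number beyond the scatter. Compound 1 stands at a limit and not at a number, so only a floor is known for the size of this step: the limit of > 10000 nM in this assay, at which 1 of the 4 values shown sits.

The compounds shown leave open whether fluoro, chloro, an amine or a carboxylic acid at the same place would act as bromo does. They also leave open whether bromo gives a similar step when the carbonyl carbon carries the pyridin-4-yl of compound 3 or the 6-methoxypyridin-3-yl of compound 2.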